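Adding an Isopropyl Group to a Urea Nitrogen

The source may hold more compounds than are shown below. What is called first, only, known or untested is meant among the compounds shown, and "the series" means these compounds.

Compound 1 `CC(C)NC(=O)N1CCN(C(=S)SCc2cn(Cc3ccc(F)cc3)nn2)CC1` and compound 2 `CC(C)NC(=O)N1CCN(C(=S)SCc2cn(Cc3ccc(Cl)cc3)nn2)CC1` differ only in the halogen on their aromatic ring. In a functional assay on MCF7 cells (Homo sapiens) for cytotoxicity, read by MTT assay, with a stated time of 72 h (a higher number here means a weaker inhibitor, a lower number a stronger inhibitor), compound 1 gives 1660 nM. For compound 2 this assay reports only a limit, > 128000 nM. The step of an at least 77-fold higher number from compound 1 to compound 2 (1.88 log units; beyond the scatter) is therefore large. Compound 3 `COc1ccc(Cn2cc(CSC(=S)N3CCN(C(N)=O)CC3)nn2)cc1` carries a methoxy group on its aromatic ring and a carbamoyl group with a free amide nitrogen. For compound 3 this assay again reports only a limit, > 128000 nM. Two of the three values sit at that limit (the limit of > 128000 nM in this assay, at which 2 of the 3 values shown sit), so compound 3 stands at the weak end of what can be read.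

Compound 4 `COc1ccc(Cn2cc(CSC(=S)N3CCN(C(=O)NC(C)C)CC3)nn2)cc1` differs from compound 3 in one place: isopropyl in place of hydrogen on an amide-type nitrogen. Among the measured compounds shown here, no measured step touches this position; the only measured step, that between compound 1 and compound 2, concerns the aromatic ring and says nothing about the urea nitrogen. For the measured compounds named here, compound 1, the one compound with a number, carries the isopropyl group, and so does compound 2, which sits at the limit. On this evidence the expected step of an at least 1.2-fold lower number from compound 3 to compound 4 (0.10 log units; that floor lies within the scatter) is uncertain. Compound 4 is estimated at 100000 nM, within 10000 nM to 300000 nM.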

Compound 4, half-maximal inhibitory concentration: 19600 nM
The estimate for compound 4 lay 5.1-fold (0.71 log units) above the measured number; the range from low to high includes it.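

For the first time this position has a step of its own: in this assay, isopropyl in place of hydrogen on the amide-type nitrogen gives an at least 6.5-fold lower number from compound 3 to compound 4 (0.81 log units; beyond the scatter), and this size is only a floor, since compound 3 has a limit and not a number: the limit of > 128000 nM in this assay, at which 2 of the 4 values shown sit.

With the isopropyl group held fixed, the group on the aromatic ring also counts: methoxy in place of chloro gives an at least 6.5-fold lower number from compound 2 to compound 4 (0.81 log units; beyond the scatter), again a floor, as compound 2 also has only a limit, while methoxy in place of fluoro gives a 12-fold higher number from compound 1 to compound 4 (1.07 log units; beyond the scatter). The isopropyl group therefore does not settle the result alone, as compound 2 carries it and still stands at a limit.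

Only hydrogen and isopropyl appear on this nitrogen, so the compounds shown cannot tell how a methyl group, a longer chain such as butyl, or a cyclohexyl ring would compare. The effect of the isopropyl group is also read in the methoxy pair only, which leaves open whether it would hold with fluoro or chloro on the aromatic ring.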